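Solubility notes: phenyl to 1-methyl-1H-pyrazol-3-yl

A few compounds are considered here, and "the series" means these few. Any claim that something is new, unique, unknown or untested is made for them only; others in the source may bear on it.

The series is followed in a physicochemical assay for solubility, read by LC-MS, in phosphate buffer, with a stated time of 24 h, at pH 7.4; on this read-out higher numbers stand for higher solubility and lower numbers for lower solubility. Compound 1 (`CN(c1ncco1)c1cnc(NCc2c(F)ccc3c2CCO3)n2cnnc12`) gives 67000 nM, and compound 2 (`O=C1c2ccccc2CN1c1cnc(NCc2c(F)ccc3c2CCO3)n2cnnc12`) gives 4000 nM. Compound 3 (`CN(c1ccccc1)c1cnc(NCc2c(F)ccc3c2CCO3)n2cnnc12`) gives < 2000 nM, which is a limit of the assay and not a number.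

Compound 4 (`CN(c1ccn(C)n1)c1cnc(NCc2c(F)ccc3c2CCO3)n2cnnc12`), not yet measured, carries 1-methyl-1H-pyrazol-3-yl in place of phenyl on a nitrogen on an aromatic ring.

The closest measured change is an at least 33-fold lower number from compound 1 to compound 3 (1.52 log units; beyond the scatter), which is large and puts phenyl in place of 1,3-oxazol-2-yl at that same place. A second large change, a 17-fold lower number from compound 1 to compound 2 (1.22 log units; beyond the scatter), swaps a different group on an aromatic carbon and bears on this one less directly. The third, an at least 2.0-fold lower number from compound 2 to compound 3 (0.30 log units; that floor lies within the scatter), adds little here.

Compound 4, like compound 1, has a five-membered aromatic ring at this place, so a large move to a higher number is expected in this assay. This expectation rests on a single pair, and the two rings differ, so a full return to the value of compound 1, 67000 nM, is not assumed. The expected change is an at least 12-fold higher number from compound 3 to compound 4 (1.09 log units; beyond the scatter). For compound 4 the estimate is 25000 nM, with an expected range of 7000 nM to 80000 nM.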

Compound 4, solubility: 130000 nM
Estimate against measurement, compound 4: 5.2-fold (0.72 log units) below; the measured number lies above the stated range.
By their numbers in this assay, from the lowest: compound 2; then compounds 1 and 4 (each within the scatter of the next). At a limit, below all of these: compound 3.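

In this assay, the result shows that a high number at this place is not confined to 1,3-oxazol-2-yl: replacing phenyl on a nitrogen on an aromatic ring with 1-methyl-1H-pyrazol-3-yl gives an at least 65-fold higher number from compound 3 to compound 4 (1.81 log units; beyond the scatter). The two five-membered aromatic rings are not separated here, since 1-methyl-1H-pyrazol-3-yl in place of 1,3-oxazol-2-yl gives a 1.9-fold higher number from compound 1 to compound 4 (0.29 log units; within the scatter), which leaves the earlier high value no longer resting on a single compound. The group of compound 2 also stays well apart from the methyl(1-methyl-1H-pyrazol-3-yl)amino group, with a 33-fold higher number from compound 2 to compound 4 (1.51 log units; beyond the scatter).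

Going by these compounds, the full size of the step from phenyl stays open, as compound 3 is held at a limit of the assay and not a number: the limit of < 2000 nM in this assay, at which 1 of the 4 values shown sits. Also open is whether a six-membered ring with a ring nitrogen, such as pyridin-2-yl, or a 1H-pyrazol-3-yl without the methyl, would stand with compound 1 and compound 4 or with compound 3.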